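The source may hold more compounds than are shown below. What is called first, only, known or untested is meant among the compounds shown, and "the series" means these compounds.

Three compounds sharing one core were measured in a functional assay on A549 cells (Homo sapiens) for antiproliferative activity, read by MTT assay, with a stated time of 72 h; on this read-out higher numbers stand for weaker inhibition and lower numbers for stronger inhibition. Compound 1 `O=C(Nc1ccc(Oc2ccnc3[nH]ccc23)cc1)c1cc2cccnc2n(-c2ccc(Cl)cc2)c1=O` gives 290 nM. Compound 2 `Cn1ccc2c(Oc3ccc(NC(=O)c4cc5cccnc5n(-c5ccccc5)c4=O)cc3)ccnc21` gives 850 nM, and compound 3 `Cn1ccc2c(Oc3ccc(NC(=O)c4cc5cccnc5n(-c5ccc(F)cc5)c4=O)cc3)ccnc21` gives 210 nM. On the numbers shown, compound 3 stands lowest, though its gap to compound 1 lies within the scatter, while the step of a 4.0-fold lower number from compound 2 to compound 3 (0.61 log units; beyond the scatter) lies beyond it.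

Compound 4 `Cn1ccc2c(Oc3ccc(NC(=O)c4cc5cccnc5n(-c5ccc(Cl)cc5)c4=O)cc3)ccnc21` has not yet been measured. It differs from compound 3 by chloro in place of fluoro on an aromatic carbon. Among the compounds with values here, no measured step covers chloro in place of fluoro at this position. The step of a 4.0-fold lower number from compound 2 to compound 3 (0.61 log units; beyond the scatter) bears on it only in showing that a halogen on this ring lowered the number. Compound 1, which carries the same chloro but lacks the methyl on the other ring, gives 290 nM, close to compound 3.

Compound 4 is therefore expected to give a number close to that of compound 3 in this assay. The step of a 1.2-fold lower number from compound 3 to compound 4 (0.07 log units; within the scatter) is expected to stay within the scatter. The estimate for compound 4 is 180 nM, ranging from 70 nM to 450 nM.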

Compound 4, half-maximal inhibitory concentration: 630 nM
Compound 4: middle estimate off by 3.5-fold (0.54 log units), on the low side; the whole stated range lies below it.
By their numbers in this assay, from the lowest: compounds 3 and 1 (each within the scatter of the next); then compounds 4 and 2 (each within the scatter of the next).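

In this assay, the two halogens prove not to be interchangeable on this ring: the change from 4-fluorophenyl to 4-chlorophenyl gives a 3.0-fold higher number from compound 3 to compound 4 (0.48 log units; beyond the scatter) and so separates them. Chloro in place of hydrogen gives only a 1.3-fold lower number from compound 2 to compound 4 (0.13 log units; within the scatter) and stays within the scatter, so the drop earlier seen with fluoro does not carry over to chloro. Within the data shown here, the methyl on the aromatic nitrogen also shows up for the first time as a single change, with a 2.2-fold higher number from compound 1 to compound 4 (0.34 log units; beyond the scatter) lying beyond the scatter.

No measurement is available that accounts for the difference between chloro and fluoro here. On these data alone, whether a methoxy group, a trifluoromethyl group or an amine in this place would track fluoro or chloro stays open, as does whether the methyl step would hold with fluoro on the ring.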